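The source may report more compounds than this note shows. Statements on the series, on what has been measured and on what is new or still open speak of the compounds shown alone.

Measured in a functional assay on HCT-116 cells (Homo sapiens) for antiproliferative activity, read by MTT assay, with a stated time of 48 h; on this read-out higher numbers stand for weaker inhibition and lower numbers for stronger inhibition:
- Compound 1 `CC(CCO)n1cnc2c(Cl)ncnc21`: > 50000 nM
- Compound 2 `CCCCCCC(CCO)n1cnc2c(Cl)nc(F)nc21`: 9960 nM

Within the data shown here, only compound 2 has a numerical value so far, which leaves no measured number to rank it against. For compound 1, the entry of > 50000 nM is a limit of the assay and not a number.

The next compound, compound 3 `CCCCCCC(CCO)n1cnc2c(Cl)ncnc21`, departs from compound 2 in a single place: hydrogen in place of fluoro on an aromatic carbon. Hydrogen takes the place of fluoro on an aromatic carbon, between two ring nitrogen atoms. Among the measured compounds shown here, no measured pair of compounds isolates this change, so this assay offers no direct guide to its size. A modest step is therefore expected, perhaps toward weaker inhibition and not far beyond the usual scatter. For the measured compounds named here, the expectation stays anchored to compound 2 at 9960 nM, the only number available. The expected change is a 1.4-fold higher number from compound 2 to compound 3 (0.15 log units; within the scatter). For compound 3 the estimated value is 14000 nM, with an expected range from 6000 nM to 35000 nM.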

Compound 3, half-maximal inhibitory concentration: 11900 nM
Estimate against measurement, compound 3: 1.2-fold (0.07 log units) above; the range from low to high includes it.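

In this assay, hydrogen in place of fluoro on the aromatic carbon between two ring nitrogen atoms gives a 1.2-fold higher number from compound 2 to compound 3 (0.08 log units; within the scatter), so this pair offers no sign that the fluoro group matters at this position. Pentyl in place of hydrogen on a saturated chain carbon, two bonds along the chain from an aromatic nitrogen, gives an at least 4.2-fold lower number from compound 1 to compound 3 (0.62 log units; beyond the scatter), the first single change here that lies beyond the scatter, and neither compound of this pair carries the fluoro group. The size of that step can be read only as a minimum, because compound 1 is given as a limit of the assay and not as a number: the limit of > 50000 nM in this assay, at which 1 of the 3 values shown sits.

The compounds shown leave open whether an amine on the aromatic carbon between two ring nitrogen atoms would stand apart from fluoro and hydrogen, which are the only two groups seen there so far. They also leave open how a longer chain than pentyl, or a chain shorter than pentyl but still longer than hydrogen, would read at the saturated chain carbon.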